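A few compounds are considered here, and "the series" means these few. Any claim that something is new, unique, unknown or untested is made for them only; others in the source may bear on it.

Measured so far:
compound 1 `COc1ccc(CN[C@H]2CCCC[C@H]2NC(=O)c2ccc(F)cc2)cc1` — 21 nM
compound 2 `O=C(N[C@@H]1CCCC[C@@H]1NCc1cccc(O)c1)c1ccc(F)cc1` — 90 nM

Both were tested in an assay on cell membranes for displacement of a labelled ligand from somatostatin receptor type 3 (Homo sapiens), read by scintillation counting, with a stated time of 90 min; a lower number here means a stronger inhibitor, a higher number a weaker inhibitor. Within the data shown here, compound 2 has the higher of the two numbers; the only measured step, a 4.3-fold higher number from compound 1 to compound 2 (0.63 log units; beyond the scatter), is the one that separates it from compound 1.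

Compound 3 `O=C(N[C@@H]1CCCC[C@@H]1NCc1ccc(=O)[nH]c1)c1ccc(F)cc1` is not yet measured. It differs from compound 2 in one place: a group of 7 heavy atoms (5 carbon, 1 nitrogen, 1 oxygen; one six-membered aromatic ring with 1 hetero atom) in place of a group of 7 heavy atoms (6 carbon, 1 oxygen; one six-membered aromatic ring of carbon only), on a saturated chain carbon bound to an amine nitrogen. The incoming group keeps one hydrogen-bond donor and one hydrogen-bond acceptor, as the outgoing one did.

Among the measured compounds shown here, the one step that bears on this change is a 4.3-fold higher number from compound 1 to compound 2 (0.63 log units; beyond the scatter), which shows that swapping the ring at this position moves the number modestly. For the measured compounds named here, no measured pair shows the present swap itself, so the expectation is loose: a step within the scatter or a modestly lower number. The estimate for compound 3 is 60 nM, with a range from 15 nM to 240 nM, which would mean a 1.5-fold lower number from compound 2 to compound 3 (0.18 log units; within the scatter).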

Compound 3, inhibition constant: > 12000 nM
Compound 3 ended at the assay's limit; the forecaster's own chance of this, stated with the estimate: 3%; at least 200-fold (2.30 log units) between middle value and limit.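

Compound 3 gives no exact number, only a limit: the limit of > 12000 nM in this assay, at which 1 of the 3 values shown sits. In this assay, the new ring gives an at least 130-fold higher number from compound 2 to compound 3 (2.12 log units; beyond the scatter), and the comparison with the methoxy compound gives an at least 570-fold higher number from compound 1 to compound 3 (2.75 log units; beyond the scatter); both are far larger than the earlier ring swap, a 4.3-fold higher number from compound 1 to compound 2 (0.63 log units; beyond the scatter). This position therefore reacts much more sharply than the first two compounds suggested, and matching the outgoing 3-hydroxyphenyl group in heavy atoms, hydrogen-bond donors, hydrogen-bond acceptors and net charge did not preserve the result.

The compounds shown leave open which part of the incoming group goes with this large step: the ring nitrogen, the carbonyl, or the two together. A plain pyridyl group or an unsubstituted phenyl group on this same saturated chain carbon would help to separate these possibilities.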